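Swapping methyl for bromo on the benzyl ring

This account rests on a few compounds, and the source may have more. Where it says the series, first, only, none or still open, it means among the compounds named here.

Measured compounds:
Compound 1 `COc1ccc(CNc2cc(OC)c(OC)c(OC)c2)cc1C` gives 73800 nM in a functional assay on KYSE-450 cells (Homo sapiens) for inhibition, read by MTT assay, with a stated time of 48 h; a higher number here means a weaker inhibitor, a lower number a stronger inhibitor.
Compound 2 `C/C=C/C=C/C(=O)N(Cc1ccc(OC)c(O)c1)c1cc(OC)c(OC)c(OC)c1` gives 180 nM in this assay.
Compound 3 `C/C=C/C(=O)N(Cc1ccc(OC)c(C)c1)c1cc(OC)c(OC)c(OC)c1` gives 32900 nM in this assay.

Compound 3 stands second highest of the three numbers in this assay: its nearest neighbour is compound 1, which differs by a 2.2-fold lower number from compound 1 to compound 3 (0.35 log units; beyond the scatter), while compound 2 is far below it. Compound 4 `C/C=C/C(=O)N(Cc1ccc(OC)c(Br)c1)c1cc(OC)c(OC)c(OC)c1` is not yet measured. It differs from compound 3 in one place: bromo in place of methyl on an aromatic carbon.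

Among the measured compounds shown here, none of the measured steps touches this position, and the only measured step, a 2.2-fold lower number from compound 1 to compound 3 (0.35 log units; beyond the scatter), concerns the nitrogen and not the benzyl ring. Compound 2 carries a different group on that ring but also a longer chain on the carbonyl, so its much lower number cannot be assigned to the ring alone. For the measured compounds named here, with no direct precedent, the expectation for compound 4 is a step of a 1.5-fold lower number from compound 3 to compound 4 (0.17 log units; within the scatter) in this assay, which is within the scatter. Compound 4 is therefore estimated at 22000 nM, with a range from 5000 nM to 90000 nM.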

Compound 4, half-maximal inhibitory concentration: 10500 nM
Beside the measured number, compound 4's estimate is 2.1-fold (0.32 log units) above it; the measured number falls inside the stated range.
By their numbers in this assay, from the lowest: compound 2; then compound 4; then compound 3; then compound 1.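

Among the compounds shown here, this is the first measured change on the benzyl ring itself: going from 4-methoxy-3-methylphenyl to 3-bromo-4-methoxyphenyl gives a 3.1-fold lower number from compound 3 to compound 4 (0.50 log units; beyond the scatter) in this assay on the read-out of cell growth inhibition. It shows that this position, ortho to a methoxy group, responds to the group it carries, even when one heavy atom is simply exchanged for another. Nothing available here explains why bromo gives the lower number.

A smaller halogen such as chloro, or a larger group such as trifluoromethyl, at the same place would show whether this result is specific to bromo. Also open, from the compounds shown here alone, is whether the same exchange keeps its size when the carbonyl carries the longer chain of compound 2.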